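Extending One Chain: From Compound 3 to Compound 4

The compounds below may be only part of what the source reports. "The series", "measured", "known", "first", "only" and "open" are said of these compounds alone.

In a functional assay on WRL68 cells (Homo sapiens) for cytotoxicity, read by MTT assay, with a stated time of 4 h (a lower number here means a stronger inhibitor, a higher number a weaker inhibitor), compound 1 `COC(=O)C1=CO[C@@H](O[C@@H]2O[C@H](COC(c3ccccc3)(c3ccccc3)c3ccccc3)[C@@H](O)[C@H](O)[C@H]2O)[C@@H]2[C@@H](C)[C@@H](O)C[C@H]12` gives 1.86 ug/mL. Compound 2 `COC(=O)C1=CO[C@@H](O[C@@H]2O[C@H](CO)[C@@H](OC(C)=O)[C@H](OC(C)=O)[C@H]2OC(C)=O)[C@@H]2[C@@H](C)[C@@H](OC(C)=O)C[C@H]12` is reported as "not active" (no number reported), with no number. Compound 3 `CCC(=O)OC[C@H]1O[C@@H](O[C@@H]2OC=C(C(=O)OC)[C@H]3C[C@H](OC(C)=O)[C@H](C)[C@@H]23)[C@H](OC(C)=O)[C@@H](OC(C)=O)[C@@H]1OC(C)=O` gives 2.65 ug/mL, which lies within the usual scatter of compound 1, so these two cannot be told apart. Compound 4 `CCCCCCCCCCCCCC(=O)OC[C@H]1O[C@@H](O[C@@H]2OC=C(C(=O)OC)[C@H]3C[C@H](OC(C)=O)[C@H](C)[C@@H]23)[C@H](OC(C)=O)[C@@H](OC(C)=O)[C@@H]1OC(C)=O` differs from compound 3 by a single change: undecyl in place of hydrogen on a saturated chain carbon, two bonds along the chain from a carbonyl carbon, with undecyl in place of hydrogen on a saturated chain carbon, two bonds along the chain from a carbonyl carbon. For the measured compounds named here, no measured pair here shows what such a change does, so the expectation is cautious. The expected step of a 1.5-fold higher number from compound 3 to compound 4 (0.18 log units; within the scatter) is a small move towards a weaker number, not clearly beyond the scatter. Compound 4 is estimated at 4 ug/mL, with an expected range of 1.5 ug/mL to 12 ug/mL.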

Compound 4, half-maximal inhibitory concentration: 58.5 ug/mL
For compound 4 the middle estimate is 15-fold (1.17 log units) below the measured one, outside the stated range (above it).
By their numbers in this assay, from the lowest: compounds 1 and 3 (each within the scatter of the next); then compound 4.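

Undecyl in place of hydrogen on a saturated chain carbon, two bonds along the chain from a carbonyl carbon, gives a 22-fold higher number from compound 3 to compound 4 (1.34 log units; beyond the scatter) in this assay and so clearly weakens the compound. For the compounds shown here, this is the first measured pair differing in one place, and it shows that this position is sensitive to a large addition of carbon chain. Chains of intermediate length, such as butyl or hexyl, and a chain ending in an amine remain open, so where the number begins to rise is unknown. Nothing measured here explains the rise.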